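A few compounds are considered here, and "the series" means these few. Any claim that something is new, unique, unknown or untested is made for them only; others in the source may bear on it.

Measured in a functional assay on HepG2 cells (Homo sapiens) for cytotoxicity, read by MTT assay, with a stated time of 72 h (on this read-out lower numbers stand for stronger inhibition and higher numbers for weaker inhibition), so far
- compound 1 `N#Cc1ccc(/C=N/NC(=O)Nc2cc3c(Nc4ccc(F)c(Cl)c4)ncnc3cc2O[C@H]2CCOC2)cc1` gives 26400 nM
- compound 2 `O=C(N/N=C/c1cccc(Cl)c1Cl)Nc1cc2c(Nc3ccc(F)c(Cl)c3)ncnc2cc1O[C@H]1CCOC1` gives 16900 nM
- compound 3 `COc1ccc(/C=N/NC(=O)Nc2cc3c(Nc4ccc(F)c(Cl)c4)ncnc3cc2O[C@H]2CCOC2)c(OC)c1OC` gives 29300 nM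

Compound 2 stands within the scatter of both other compounds. Compound 4 `O=C(N/N=C/c1ccc(O)cc1O)Nc1cc2c(Nc3ccc(F)c(Cl)c3)ncnc2cc1O[C@H]1CCOC1` has 2,4-dihydroxyphenyl in place of 2,3-dichlorophenyl on a carbon with a double bond to nitrogen. Three measured exchanges at that carbon bear on this change. The steps are a 1.6-fold lower number from compound 1 to compound 2 (0.19 log units; within the scatter) and a 1.1-fold higher number from compound 1 to compound 3 (0.05 log units; within the scatter) and a 1.7-fold higher number from compound 2 to compound 3 (0.24 log units; within the scatter) and all lie within the scatter. Among the measured compounds shown here, none of the measured compounds carries a dihydroxyphenyl group, so this group is untested. No step beyond the scatter is therefore expected in this assay. The estimate means a 1.2-fold higher number from compound 2 to compound 4 (0.09 log units; within the scatter) as the expected step. Compound 4 is expected at 21000 nM (range 9000 nM to 48000 nM).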

Compound 4, half-maximal inhibitory concentration: 4530 nM
Beside the measured number, compound 4's estimate is 4.6-fold (0.67 log units) above it; the whole stated range lies above it.
By their numbers in this assay, from the lowest: compound 4; then compounds 2, 1 and 3 (each within the scatter of the next).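

In this assay, the group on this carbon now separates the compounds: exchanges among the earlier groups stayed within the scatter, whereas 2,4-dihydroxyphenyl gives a 3.7-fold lower number from compound 2 to compound 4 (0.57 log units; beyond the scatter), a 5.8-fold lower number from compound 1 to compound 4 (0.77 log units; beyond the scatter) and a 6.5-fold lower number from compound 3 to compound 4 (0.81 log units; beyond the scatter). Unlike 2,3-dichlorophenyl, 2,4-dihydroxyphenyl carries hydrogen-bond donors. Nothing available ties the shift to these donors or to any other property.

Going by these compounds, whether a phenyl with a single hydroxy group would give the same shift remains open. So does the outcome with an amine in place of the hydroxy groups.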